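The compounds below may be only part of what the source reports. "The series", "measured", "known", "first", "only" and "open" are said of these compounds alone.

In a functional assay on MCF7 cells (Homo sapiens) for inhibition (a higher number here means a weaker inhibitor, a lower number a stronger inhibitor), three compounds sharing one core have been measured, and they differ at a single aromatic carbon. Compound 1 `O=C1O/C(=C\Cn2cc(I)c(=O)[nH]c2=O)C(OCc2ccccc2)=C1OCc1ccccc1` carries iodo and gives 70000 nM while compound 2 `O=C1O/C(=C\Cn2ccc(=O)[nH]c2=O)C(OCc2ccccc2)=C1OCc1ccccc1` carries hydrogen instead and gives 20000 nM as its result. Compound 3 `O=C1O/C(=C\Cn2cc(Br)c(=O)[nH]c2=O)C(OCc2ccccc2)=C1OCc1ccccc1` carries bromo and gives 40000 nM which lies within the scatter of both others. Compound 4 `O=C1O/C(=C\Cn2cc(F)c(=O)[nH]c2=O)C(OCc2ccccc2)=C1OCc1ccccc1` has not been measured and has fluoro in place of bromo on an aromatic carbon compared with compound 3 (fluoro in place of bromo on an aromatic carbon). All three measured steps bear on this swap. Only a 3.5-fold lower number from compound 1 to compound 2 (0.54 log units; beyond the scatter) clears the scatter, whereas a 1.8-fold lower number from compound 1 to compound 3 (0.24 log units; within the scatter) and a 2.0-fold higher number from compound 2 to compound 3 (0.30 log units; within the scatter) do not. Going by the values given here, no fluoro compound has been measured yet, so in this assay only a small step is expected, leaning loosely toward compound 2 at 20000 nM as the reference. Among the compounds with values here, the estimated change is a 1.6-fold lower number from compound 3 to compound 4 (0.20 log units; within the scatter) and would be no larger than the steps already seen. For compound 4 the expected value is 25000 nM within an estimated range from 9000 nM to 60000 nM for a single measurement.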

Compound 4, half-maximal inhibitory concentration: 60000 nM
Compound 4: the middle estimate sits 2.4-fold (0.38 log units) below what was measured; the measured number falls inside the stated range.
By their numbers in this assay, from the lowest: compounds 2, 3, 4 and 1 (each within the scatter of the next, the first and the last beyond it).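

In this assay, going by these compounds alone, fluoro at this aromatic carbon stands apart from hydrogen, with a 3.0-fold higher number from compound 2 to compound 4 (0.48 log units; beyond the scatter), so iodo is no longer the only group to do so. The halogens themselves cannot be told apart, since a 1.5-fold higher number from compound 3 to compound 4 (0.18 log units; within the scatter) and a 1.2-fold lower number from compound 1 to compound 4 (0.07 log units; within the scatter) both stay within the scatter. Bromo goes against a clean split between hydrogen and halogen. Its own step, a 2.0-fold higher number from compound 2 to compound 3 (0.30 log units; within the scatter), also stays within the scatter, so the pattern holds only for fluoro and iodo.

Nothing available gives a reason for these numbers. Still open, as far as these compounds go, is where an amine, a methyl group or a hydroxyl group at this carbon would fall, and whether any group here could bring the number clearly under that of compound 2, at 20000 nM.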